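Chloro Substitution on Two Imidazole-Bearing Phenyl Cores

The source may hold more compounds than are shown below. What is called first, only, known or untested is meant among the compounds shown, and "the series" means these compounds.

Measured compounds:
compound 1, `Cn1cncc1-c1ccccc1N` — 1700000 nM
compound 2, `Cn1cncc1-c1cc(Cl)ccc1N` — 1200000 nM
compound 3, `Oc1ccccc1-n1ccnc1` — 16000 nM

Compounds 1 and 2 share one core; in an assay on cells for inhibition of Indoleamine 2,3-dioxygenase 1 (Homo sapiens), read by HPLC, with a stated time of 20 min (on this read-out lower numbers stand for stronger inhibition and higher numbers for weaker inhibition), compound 1 gives 1700000 nM and compound 2 gives 1200000 nM. The change between them is chloro in place of hydrogen on an aromatic carbon, and it made a 1.4-fold lower number from compound 1 to compound 2 (0.15 log units; within the scatter). Compound 3, with a different core, gives 16000 nM in this assay, the lowest of the three numbers; the difference between the two cores is not broken down here. Compound 4, `Oc1ccc(Cl)cc1-n1ccnc1`, has not yet been measured. It differs from compound 3 by chloro in place of hydrogen on an aromatic carbon. This is the same kind of change as that from compound 1 to compound 2, though the surroundings differ: in compound 2 the chloro is meta to a group of 6 heavy atoms and para to an amino group, in compound 4 meta to a group of 5 heavy atoms and para to a hydroxy group. Because a 1.4-fold lower number from compound 1 to compound 2 (0.15 log units; within the scatter) stayed within the scatter, the step from compound 3 to compound 4 is expected to be similarly small, a 1.5-fold lower number from compound 3 to compound 4 (0.16 log units; within the scatter). For compound 4 the estimate in this assay is 11000 nM, expected between 4000 nM and 30000 nM.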

Compound 4, half-maximal inhibitory concentration: 2100 nM
For compound 4 the middle estimate is 5.2-fold (0.72 log units) above the measured one, and the stated range ends above it.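

In this assay, chloro in place of hydrogen on an aromatic carbon gave a 7.6-fold lower number from compound 3 to compound 4 (0.88 log units; beyond the scatter), a step that lies beyond the scatter. Within the data shown here, the size of the step did not carry over from one core to the other: the same change on two cores in this assay, a 1.4-fold lower number (0.15 log units; within the scatter) from compound 1 to compound 2 and a 7.6-fold lower number (0.88 log units; beyond the scatter) from compound 3 to compound 4, 5.4-fold (0.73 log units) apart, beyond the scatter of two such steps Only the step on the core of compound 3 lies beyond the scatter, and a comparison of two cores gives no rule for any third core, nor does it show why the two steps differ in size.

The compounds shown carry chloro at only one place on each core, and they leave open whether fluoro, bromo, methoxy or a nitrile at that place would give a step like that of chloro. They also do not separate which difference between the two cores, the hydroxy group against the amino group or some other part of the structure, sets the two steps apart.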